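The source may report more compounds than this note shows. Statements on the series, on what has been measured and on what is new or still open speak of the compounds shown alone.

Values in a functional assay on K562 cells (Homo sapiens) for cytotoxicity, read by trypan blue exclusion, with a stated time of 96 h; a higher number here means a weaker inhibitor of growth, a lower number a stronger inhibitor of growth:
- compound 1 `COc1ccc(NS(=O)(=O)/C=C/c2c(OC)cc(OC)cc2OC)cc1`: 75 nM
- compound 2 `COc1cc(OC)c(/C=C/S(=O)(=O)Nc2ccc(OC)c(O)c2)c(OC)c1`: 15 nM

Compound 2 holds the lower of the two numbers, making it the stronger inhibitor of growth of this pair. The next compound is compound 3 `COc1cc(OC)c(/C=C/S(=O)(=O)Nc2ccc(OC)c(N)c2)c(OC)c1`, with the change amino in place of hydroxy on an aromatic carbon, ortho to a methoxy group. Among the measured compounds shown here, one measured step bears on this, a 5.0-fold lower number from compound 1 to compound 2 (0.70 log units; beyond the scatter), a modest step with hydroxy in place of hydrogen on that same carbon. For the measured compounds named here, it shows that replacing hydrogen there can lower the number in this assay, but no measured compound carries amino, so the swap itself is untested. With no evidence for a direction, no step beyond the scatter is expected. The expected step is no change at the digits printed from compound 2 to compound 3 (within the scatter). For compound 3 the estimated value is 15 nM, with an expected range of 5 nM to 50 nM.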

Compound 3, concentration for 50% growth inhibition: 3 nM
Beside the measured number, compound 3's estimate is 5.0-fold (0.70 log units) above it, outside the stated range (below it).
By their numbers in this assay, from the lowest: compound 3; then compound 2; then compound 1.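

In this assay, amino in place of hydroxy, ortho to a methoxy group, gives a 5.0-fold lower number from compound 2 to compound 3 (0.70 log units; beyond the scatter), so this position separates two groups that match in heavy-atom count, hydrogen-bond donors and hydrogen-bond acceptors. Measured against hydrogen at the same carbon, amino gives a 25-fold lower number from compound 1 to compound 3 (1.40 log units; beyond the scatter), which shows that hydroxy does not mark the lowest number reachable at this position. Nothing among the available data explains the difference between amino and hydroxy here.

Open, from the compounds shown here alone, is how a methylamino or acetamido group, or a fluorine, would read at this carbon, and so whether the gain extends beyond the free amine. Also open, going by these compounds, is whether the amino result depends on the neighbouring methoxy group, since all three compounds carry it.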